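Single methoxy in place of carboxy: an expected step

The compounds below may be only part of what the source reports. "The series", "measured", "known", "first", "only" and "open" are said of these compounds alone.

Measured compounds:
compound 1, `COc1cc2[nH]c(=O)c(=O)oc2cc1OC`, 45%
compound 2, `O=C(O)c1ccc2[nH]c(=O)c(=O)oc2c1`, 7%

Of the compounds shown here, two have been measured in a functional assay on the whole organism for inhibition, with Rattus norvegicus as the target, at a dose of 25 mg/kg; on this read-out lower numbers stand for less inhibition and higher numbers for more inhibition at the one dose given (going by the name of the read-out). Compound 1 gives 45% in this assay, while compound 2 gives 7% in the same read-out. Compound 2 therefore stands lowest of the two numbers, and its nearest neighbour, compound 1, lies a good way higher, a gap that goes beyond the usual scatter of repeated measurements.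

The unmeasured compound 3, `COc1ccc2[nH]c(=O)c(=O)oc2c1`, differs from compound 2 in one place: methoxy in place of carboxy on an aromatic carbon. Going by the values given here, compound 3 carries the methoxy at the place where compound 2 carries the carboxy, so that compound 3 shares the methoxy with compound 1, which bears two of them, though compound 1 and compound 2 differ in more than one place and no single step between them is available.

Given that compound 1 reaches 45% and compound 2 only 7%, the step from compound 2 to compound 3 is expected to be upward and beyond the scatter, with a number 23 percentage points higher from compound 2 to compound 3 (beyond the scatter). Compound 3 is accordingly estimated at 30%, within a range of 10% to 55%.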

Compound 3, a percentage reported as inhibition, in the whole organism at one dose (the size of the read-out at that dose, not a potency): 33%
Estimate against measurement, compound 3: 3 percentage points below, within the range that was stated.
By their numbers in this assay, from the lowest: compound 2; then compound 3; then compound 1.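

In this assay, going by these compounds alone, methoxy in place of carboxy on an aromatic carbon gives a number 26 percentage points higher from compound 2 to compound 3 (beyond the scatter), the first comparison in which only this group changes, and it shows that the read-out at this position responds to the exchange in favour of methoxy. Hydrogen in place of methoxy on an aromatic carbon gives a number 12 percentage points lower from compound 1 to compound 3 (beyond the scatter), so the loss of one methoxy from compound 1 also registers beyond the scatter, and the second methoxy of compound 1 adds to what compound 3 retains with its single methoxy. Nothing in the data offers an explanation for either step.

The compounds shown leave open whether the gain at this aromatic carbon belongs to methoxy in particular or would also come with an amine, a chlorine atom or a longer chain such as ethoxy. They also leave open how much of the gain reflects the presence of methoxy and how much the absence of carboxy, a question that hydrogen at this same carbon would address, and all of this rests on a single dose in this assay.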